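A few compounds are considered here, and "the series" means these few. Any claim that something is new, unique, unknown or untested is made for them only; others in the source may bear on it.

Among the measured compounds shown here, compound 1 `CCn1c(C(=O)NCCN)ccc1C(CC)(CC)c1ccc(OCCC(O)(CC)CC)c(C)c1` carries the (2-aminoethyl)amino group on the carbonyl carbon and is the one member of the set with a number rather than a limit: in a functional assay on Caco-2 cells (Homo sapiens) for antiproliferative activity, read by MTT assay, with a stated time of 48 h (a higher number here means a weaker inhibitor, a lower number a stronger inhibitor), compound 1 gives 1740 nM. Compound 2 `C=CCN(C)C(=O)c1ccc(C(CC)(CC)c2ccc(OCCC(O)(CC)CC)c(C)c2)n1CC` returns only a limit in this assay, > 50000 nM. Compound 3 `CCn1c(C(=O)Nc2ccc(OC(F)(F)F)cc2)ccc1C(CC)(CC)c1ccc(OCCC(O)(CC)CC)c(C)c1` likewise returns only a limit in this assay, > 50000 nM. Both changes at the carbonyl carbon therefore read as large losses: an at least 28-fold higher number from compound 1 to compound 2 (1.45 log units; beyond the scatter) and an at least 28-fold higher number from compound 1 to compound 3 (1.45 log units; beyond the scatter). The comparison a step that the two limits leave unreadable from compound 2 to compound 3 cannot be read, given (the limit of > 50000 nM in this assay, at which 2 of the 3 values shown sit).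

Compound 4 `CCn1c(C(=O)N(C)CC(=O)O)ccc1C(CC)(CC)c1ccc(OCCC(O)(CC)CC)c(C)c1` alters the same site once more: (carboxymethyl)(methyl)amino in place of (2-aminoethyl)amino on a carbonyl carbon. The two measured steps bear directly on it, since each replaced the (2-aminoethyl)amino group and each ended at the limit, and compound 2 with its allyl(methyl)amino group is the closer match to the (carboxymethyl)(methyl)amino group now entering. A large upward step in this assay is therefore expected, with a real chance that only a limit is returned. The expected step is a 17-fold higher number from compound 1 to compound 4 (1.24 log units; beyond the scatter). Compound 4 is estimated at 30000 nM, between 8000 nM and 60000 nM.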

Compound 4, half-maximal inhibitory concentration: 2740 nM
Compound 4: middle estimate off by 11-fold (1.04 log units), on the high side, outside the stated range (below it).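

In this assay, replacing the (2-aminoethyl)amino group on the carbonyl carbon does not always end at a limit: the (carboxymethyl)(methyl)amino group gives a result that cannot be told apart from the parent (a 1.6-fold higher number from compound 1 to compound 4 (0.20 log units; within the scatter)). A terminal amine on this chain is therefore not required for a measured number, since compound 4 has a carboxylic acid at the end of its chain instead. The contrast with the aryl amide is wide (an at least 18-fold lower number from compound 3 to compound 4 (1.26 log units; beyond the scatter)), and the step from the allyl(methyl)amino amide is as wide (an at least 18-fold lower number from compound 2 to compound 4 (1.26 log units; beyond the scatter)), so a methyl on the amide-type nitrogen does not by itself account for the loss seen with compound 2, and the exchange of carboxy for vinyl on the saturated chain carbon separates a measured number from a limit.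

The step between compound 2 and compound 3 cannot be read, and the two steps to compound 4 give only a minimum size: the limit of > 50000 nM in this assay, at which 2 of the 4 values shown sit. As far as these compounds go, what a methyl ester in place of the carboxylic acid, or a longer chain ending in an amine, would give at this position remains open.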